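The compounds below may be only part of what the source reports. "The series", "measured", "known", "first", "only" and "open" are said of these compounds alone.

Compound 1 `C=C1C(=O)N(c2ccccc2)N(c2ccccc2)C1c1ccccc1` and compound 2 `C=C1C(=O)N(c2ccccc2)N(c2ccccc2)C1C` share one core and differ only on a saturated ring carbon. In a functional assay on HL-60 cells (Homo sapiens) for inhibition, read by MTT assay, with a stated time of 48 h (on this read-out higher numbers stand for weaker inhibition and lower numbers for stronger inhibition), compound 1 gives 1610 nM, and compound 2 gives 5850 nM, the higher of the two numbers. The step of a 3.6-fold higher number from compound 1 to compound 2 (0.56 log units; beyond the scatter) is the only measured one that bears on compound 3 `C=CCC1C(=C)C(=O)N(c2ccccc2)N1c1ccccc1`, which carries vinyl in place of hydrogen on a saturated chain carbon bound to a saturated ring carbon. The allyl adds back some of what the change from phenyl to methyl took away, so a downward step no larger than that one is expected in this assay. For compound 3 the expected step is a 1.7-fold lower number from compound 2 to compound 3 (0.22 log units; within the scatter). Compound 3 is therefore estimated at 3500 nM, with a range from 1200 nM to 9000 nM.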

Compound 3, half-maximal inhibitory concentration: 1320 nM
The estimate for compound 3 lay 2.7-fold (0.42 log units) above the measured number; the measured number falls inside the stated range.
By their numbers in this assay, from the lowest: compounds 3 and 1 (each within the scatter of the next); then compound 2.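

In this assay, going from methyl to allyl on the saturated ring carbon gives a 4.4-fold lower number from compound 2 to compound 3 (0.65 log units; beyond the scatter) and so shows that this position responds to the group's extension. Allyl in place of phenyl gives a 1.2-fold lower number from compound 1 to compound 3 (0.09 log units; within the scatter) and so shows that, among these compounds, an aromatic ring on this carbon is not required to reach the phenyl compound's level. Nothing at hand explains either step. Open, going by these compounds, is whether propyl would match allyl, which would show if the double bond matters, and how an amine or a carboxylic acid at this position would read.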